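The source may report more compounds than this note shows. Statements on the series, on what has been measured and on what is new or still open speak of the compounds shown alone.

Compound 1, with the structure `CC(=O)N(C)c1ccc2[nH]c(-c3n[nH]c4ccccc34)cc2n1`, has been tested in a functional assay on HCT-116 cells (Homo sapiens) for antiproliferative activity, read by MTT assay, with a stated time of 72 h (on this read-out higher numbers stand for weaker inhibition and lower numbers for stronger inhibition), where compound 1 gives 14800 nM. Among the three measured compounds that number stands second highest. Compound 2, with the structure `CN(C(=O)CCc1ccccc1)c1ccc2[nH]c(-c3n[nH]c4ccccc34)cc2n1`, gives 11200 nM, and compound 3, with the structure `CN(C(=O)c1ccco1)c1ccc2[nH]c(-c3n[nH]c4ccccc34)cc2n1`, gives 30000 nM. The step of a 1.3-fold lower number from compound 1 to compound 2 (0.12 log units; within the scatter) stays within the scatter, while the step of a 2.0-fold higher number from compound 1 to compound 3 (0.31 log units; beyond the scatter) and the step of a 2.7-fold higher number from compound 2 to compound 3 (0.43 log units; beyond the scatter) are both modest and beyond it.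

Compound 4, with the structure `Cc1ccc(S(=O)(=O)N(C)c2ccc3[nH]c(-c4n[nH]c5ccccc45)cc3n2)cc1`, has not yet been measured. It differs from compound 1 in one place: (4-methylphenyl)sulfonyl in place of acetyl on a nitrogen on an aromatic ring. Among the measured compounds shown here, none of the measured steps swaps the acetyl for a sulfonyl group, so no direct precedent exists. The nearest hint is that placing furan-2-yl on the carbonyl carbon in the step of a 2.0-fold higher number from compound 1 to compound 3 (0.31 log units; beyond the scatter) gave a modestly higher number, whereas lengthening the chain in the step of a 1.3-fold lower number from compound 1 to compound 2 (0.12 log units; within the scatter) changed little. A step of similar or slightly larger size toward a higher number is therefore expected, but with wide uncertainty. For compound 4 the value expected in this assay is 22000 nM, within a range from 7000 nM to 70000 nM. This estimate means a step of a 1.5-fold higher number from compound 1 to compound 4 (0.17 log units; within the scatter), expected only tentatively.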

Compound 4, half-maximal inhibitory concentration: 13300 nM
Compound 4: middle estimate off by 1.7-fold (0.22 log units), on the high side; low and high end bracket the measured number.
By their numbers in this assay, from the lowest: compounds 2, 4 and 1 (each within the scatter of the next); then compound 3.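

In this assay, among the compounds shown here, the nitrogen on the aromatic ring now carries a sulfonyl group for the first time, and the much larger (4-methylphenyl)sulfonyl leaves the result within the scatter of the amides: acetyl gives way to it in a 1.1-fold lower number from compound 1 to compound 4 (0.05 log units; within the scatter), and phenethylcarbonyl gives way to it in a 1.2-fold higher number from compound 2 to compound 4 (0.07 log units; within the scatter). A carbonyl at this place is therefore not required to keep the number of compound 1, and a new aromatic ring can be added here without a measurable loss. Compound 3 goes against any picture of this place as indifferent to its group, since exchanging its (furan-2-yl)carbonyl gives a 2.3-fold lower number from compound 3 to compound 4 (0.35 log units; beyond the scatter), so the group on this nitrogen can matter, though only modestly in these compounds. Nothing measured here explains why the furan-bearing compound 3 stands apart.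

From the compounds shown here alone, it remains open whether a methylsulfonyl group, a plain benzoyl group, or a chain ending in an amine or a carboxylic acid would group with compounds 1, 2 and 4 or with compound 3. Going by these compounds, it is also open what would happen if hydrogen or a longer chain replaced the methyl on this nitrogen.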